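The compounds below may be only part of what the source reports. "The series", "measured", "known", "first", "only" and "open" are said of these compounds alone.

Compound 1 `COc1cc(Cn2cnc3c(Cl)ncnc32)cc(OC)c1OC`: > 50000 nM, a limit
Compound 2 `COc1ccc(Cn2cnc3c(Cl)nc(Cl)nc32)cc1OC`: 7000 nM
Compound 3 `COc1cc(Cn2cnc3c(Cl)nc(Cl)nc32)cc(OC)c1`: 4600 nM

All three compounds were tested in a functional assay on K562 cells (Homo sapiens) for antiproliferative activity, read by MTT assay, with a stated time of 48 h; a higher number here means a weaker inhibitor of growth, a lower number a stronger inhibitor of growth. The entry for compound 1, > 50000 nM, is a limit and not a number. Compound 2 gives 7000 nM and compound 3 gives 4600 nM, two values within the usual scatter of each other. Compound 4 `COc1cc(Cn2cnc3c(Cl)nc(Cl)nc32)cc(OC)c1OC` takes compound 3 and puts methoxy in place of hydrogen on an aromatic carbon, ortho to two methoxy groups and para to a large group: methoxy in place of hydrogen on an aromatic carbon. Among the measured compounds shown here, no measured pair shows this exact change. Compound 2 at 7000 nM and compound 3 at 4600 nM both carry methoxy groups, so no shift beyond the scatter is expected. The expected size is a 1.1-fold higher number from compound 3 to compound 4 (0.04 log units; within the scatter). For compound 4 the estimated value is 5000 nM, with an expected range from 1500 nM to 20000 nM.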

Compound 4, concentration for 50% growth inhibition: 4300 nM
The estimate for compound 4 lay 1.2-fold (0.07 log units) above the measured number; the range from low to high includes it.
By their numbers in this assay, from the lowest: compounds 4, 3 and 2 (each within the scatter of the next). At a limit, above all of these: compound 1.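

In this assay, methoxy in place of hydrogen at this position, ortho to two methoxy groups and para to a large group, is tolerated: a 1.1-fold lower number from compound 3 to compound 4 (0.03 log units; within the scatter). The comparison with the other dimethoxy compound agrees: a 1.6-fold lower number from compound 2 to compound 4 (0.21 log units; within the scatter). Chloro in place of hydrogen on an aromatic carbon gives a far larger step, an at least 11-fold lower number from compound 1 to compound 4 (1.06 log units; beyond the scatter), but compound 1 gives only a limit, so the true size of this step stays unknown: the limit of > 50000 nM in this assay, at which 1 of the 4 values shown sits.

Going by these compounds, whether an amine or a carboxylic acid at this position would move the number beyond the scatter remains open. So does whether a longer chain in place of methoxy would be tolerated here.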